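A few compounds are considered here, and "the series" means these few. Any claim that something is new, unique, unknown or untested is made for them only; others in the source may bear on it.

Compound 1 `CCO/C(O)=C1\C(COCCn2ccnn2)=NC(C)=C(C(=O)OC)C1c1cccc(Cl)c1Cl` is a dihydropyridine-type ester bearing a side chain that ends in a triazole ring. In a functional assay (aorta) with Rattus norvegicus as the target (a higher number here means a weaker inhibitor, a lower number a stronger inhibitor), compound 1 gives 5.01 nM. Compound 2 `CCO/C(O)=C1\C(COCCn2c(C)nc(C)c2C)=NC(C)=C(C(=O)OC)C1c1ccccc1Cl` carries a trimethylated imidazole on the same kind of chain and a singly chlorinated aryl ring, and in this assay compound 2 gives 5.01 nM. The two values are level with each other within the scatter, so neither compound can be called the stronger inhibitor. Compound 3 `CCO/C(O)=C1\C(COCCN2CC(=O)N(C)C2=O)=NC(C)=C(C(=O)OC)C1c1cccc(Cl)c1Cl` has not been measured. It differs from compound 1 in one place: 3-methyl-2,4-dioxoimidazolidin-1-yl in place of 1H-1,2,3-triazol-1-yl on a saturated chain carbon, two bonds along the chain from an oxygen on a saturated carbon. Among the measured compounds shown here, no measured pair shows the effect of such an exchange, so no direction is secured. The step from the triazole to the methylated dioxoimidazolidine is expected to stay small, with a slight lean toward a weaker inhibitor, giving a 1.3-fold higher number from compound 1 to compound 3 (0.11 log units; within the scatter). Compound 3 is therefore estimated at 6.5 nM, with a range from 2 nM to 20 nM.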

Compound 3, half-maximal inhibitory concentration: 5.01 nM
Compound 3: the middle estimate sits 1.3-fold (0.11 log units) above what was measured; measured number inside the range.
By their numbers in this assay, from the lowest: compounds 1, 2 and 3 (each within the scatter of the next).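

Replacing the 1H-1,2,3-triazol-1-yl on a saturated chain carbon, two bonds along the chain from an oxygen on a saturated carbon, with 3-methyl-2,4-dioxoimidazolidin-1-yl gives, in this assay, no change at the digits printed from compound 1 to compound 3 (within the scatter). This is the first pair shown that differs in one place only, so the end of this chain can now be read directly: a five-membered aromatic ring of 5 heavy atoms and a five-membered non-aromatic ring of 8 heavy atoms with 2 double bonds give the same reading. Nothing available explains why these two groups read alike.

As far as these compounds go, whether a simple amine or a carboxylic acid at the end of the chain would also read the same remains open. So does the effect of a longer chain carrying the same rings.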